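Benzyl to Phenyl on the Amide Nitrogen

The source may report more compounds than this note shows. Statements on the series, on what has been measured and on what is new or still open speak of the compounds shown alone.

Of the compounds shown here, three built on one shared core have been measured in a functional assay on the whole organism (Ear) for inhibition, with Mus musculus as the target, at a dose of 40 mg/kg by the oral route; on this read-out higher numbers stand for more inhibition at the one dose given (going by the name of the read-out) and lower numbers for less inhibition. Compound 1 `CNC(=O)c1cc(-c2ccc(F)cc2F)ccc1OC(C)=O` gives 48.8%, compound 2 `CCNC(=O)c1cc(-c2ccc(F)cc2F)ccc1OC(C)=O` gives 5.38%, and compound 3 `CC(=O)Oc1ccc(-c2ccc(F)cc2F)cc1C(=O)NCc1ccccc1` gives 34.1%. Compound 3 thus stands second highest of the three: compound 1 lies above it and compound 2 lies well below it. The measured steps are a number 43.4 percentage points lower from compound 1 to compound 2 (beyond the scatter), a number 14.7 percentage points lower from compound 1 to compound 3 (beyond the scatter) and a number 28.7 percentage points higher from compound 2 to compound 3 (beyond the scatter).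

Compound 4 `CC(=O)Oc1ccc(-c2ccc(F)cc2F)cc1C(=O)Nc1ccccc1` has not yet been measured. It differs from compound 3 in one place: phenyl in place of benzyl on an amide-type nitrogen. Among the compounds with values here, no measured pair exchanges benzyl for phenyl on the amide nitrogen, so the three steps bear on it only loosely. They show that methyl on the saturated chain carbon bound to the amide nitrogen costs a large amount in this assay, while phenyl on that chain carbon costs a modest amount. Removing the chain carbon altogether is a change of a kind not yet seen here, so a modest step in either direction is expected rather than none. The expected step is a number 4.1 percentage points lower from compound 3 to compound 4 (within the scatter). Compound 4 is therefore estimated at 30%, with a range from 8% to 55%.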

Compound 4, a percentage reported as inhibition, in the whole organism at one dose (the size of the read-out at that dose, not a potency): 23.2%
For compound 4 the middle estimate is 6.8 percentage points above the measured one; the range from low to high includes it.
By their numbers in this assay, from the lowest: compound 2; then compound 4; then compound 3; then compound 1.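

Phenyl in place of benzyl on the amide-type nitrogen lowers the number in this assay (a number 10.9 percentage points lower from compound 3 to compound 4 (beyond the scatter)), so at this position an aromatic ring bound to the nitrogen itself gives less than the same ring carried on a saturated chain carbon. Set against the two alkyl groups, phenyl gives a mixed result, higher than ethyl (a number 17.8 percentage points higher from compound 2 to compound 4 (beyond the scatter)) but lower than methyl (a number 25.6 percentage points lower from compound 1 to compound 4 (beyond the scatter)), so neither of the aromatic groups seen so far matches the methyl amide, yet both stand clear of the ethyl amide. Nothing available here explains why these groups rank as they do.

The compounds shown leave open how a longer chain such as propyl or phenethyl would stand on this nitrogen, and so whether the rise from phenyl to benzyl continues once the ring is carried further out. They also leave open whether a phenyl ring bearing a fluorine or methoxy group, or a pyridyl ring in its place, would lift compound 4 towards compound 3 or compound 1.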